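This account rests on a few compounds, and the source may have more. Where it says the series, first, only, none or still open, it means among the compounds named here.

In a functional assay on NCI-H322M cells (Homo sapiens) for inhibition, read by sulforhodamine B assay, with a stated time of 48 h (on this read-out higher numbers stand for weaker inhibition of growth and lower numbers for stronger inhibition of growth), compound 1 `COc1ccc(-c2cc(/C=C/C(=O)c3ccc(N)cc3)[nH]n2)cc1` gives 1840 nM. Compound 2 `COc1ccc(-c2cc(/C=C/C(=O)c3ccc(N)cc3)[nH]n2)cc1OC` carries one methoxy group more, and in this assay compound 2 gives 4340 nM. The step between them, a 2.4-fold lower number from compound 2 to compound 1 (0.37 log units; beyond the scatter), comes from hydrogen in place of methoxy on an aromatic carbon. Compound 3 `COc1cc(C(=O)/C=C/c2cc(-c3cc(OC)c(OC)c(OC)c3)n[nH]2)cc(OC)c1OC` gives 2000 nM in this assay; its number stands within the scatter of compound 1 and beyond the scatter of compound 2. The difference between the core of compound 3 and the core of compound 2 is not broken down here. Compound 4 `COc1ccc(-c2cc(/C=C/C(=O)c3cc(OC)c(OC)c(OC)c3)[nH]n2)cc1OC` has not yet been measured in this assay. It differs from compound 3 by hydrogen in place of methoxy on an aromatic carbon; this is the same kind of change as that from compound 2 to compound 1, though here the place is also meta to a methoxy group. Because the earlier step was a 2.4-fold lower number from compound 2 to compound 1 (0.37 log units; beyond the scatter), a step of similar size is expected for compound 4 in this assay, estimated as a 2.0-fold lower number from compound 3 to compound 4 (0.30 log units; within the scatter). Compound 4 is thus expected to give about 1000 nM in this assay. The estimate for compound 4 runs from 400 nM to 3000 nM.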

Compound 4, concentration for 50% growth inhibition: 2020 nM
The estimate for compound 4 lay 2.0-fold (0.31 log units) below the measured number, within the range that was stated.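

In this assay, replacing methoxy with hydrogen on the core of compound 3 gives a 1.0-fold higher number from compound 3 to compound 4 (0.00 log units; within the scatter), so the step seen on the core of compound 1 does not appear here as a step beyond the scatter. This does not establish that the two cores respond differently to the change, for the two steps cannot be told apart: the same change on two cores in this assay, a 2.4-fold lower number (0.37 log units; beyond the scatter) from compound 2 to compound 1 and a 1.0-fold higher number (0.00 log units; within the scatter) from compound 3 to compound 4, 2.4-fold (0.38 log units) apart, within the scatter of two such steps With only one pair on each core, the compounds shown neither confirm that the size of the step carries from one core to the other nor show that it fails to carry, and they support no general rule for the series.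

Going by these compounds, it remains open whether a hydroxy group, a fluorine atom or an ethoxy group in place of this methoxy would read differently from hydrogen on either core. On these data alone, it also remains open how the same change would behave on a core carrying a carboxylic acid in place of the amine of compound 1.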